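Aryl sulfonamide variation on the shared core

The source may hold more compounds than are shown below. What is called first, only, known or untested is meant among the compounds shown, and "the series" means these compounds.

Compound 1 `C=Cc1ccc(S(=O)(=O)Nc2ccc3oc(-c4ccccc4)nc3c2)cc1`: > 63000 nM
Compound 2 `COc1cccc(S(=O)(=O)Nc2ccc3oc(-c4ccccc4)nc3c2)c1`: > 63000 nM

Both values shown for an assay on isolated protein for inhibition of malate dehydrogenase, mitochondrial (Sus scrofa), with stated times of 45 min and 30 min (on this read-out higher numbers stand for weaker inhibition and lower numbers for stronger inhibition), are limits of the assay rather than numbers. Compound 1 gives > 63000 nM, a limit. Compound 2 likewise gives > 63000 nM, a limit. The step that the two limits leave unreadable from compound 1 to compound 2 is therefore unreadable, and compound 2 stands only at the limit, in line with the limit of > 63000 nM in this assay, at which 2 of the 2 values shown sit.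

The next change is 2-fluorophenyl in place of 3-methoxyphenyl on a sulfonyl sulfur, which yields compound 3 `O=S(=O)(Nc1ccc2oc(-c3ccccc3)nc2c1)c1ccccc1F`. Going by the values given here, the only measured step, a step that the two limits leave unreadable from compound 1 to compound 2, also exchanges the aryl group on the sulfonyl sulfur, and since it cannot be read, it gives neither a direction nor a size for the present change; no other measured step bears on it. With both measured compounds sitting at the limit, compound 3 is expected most likely to return a limit as well, so the step that the limit leaves unreadable from compound 2 to compound 3 is an estimate of no readable movement rather than a prediction of gain or loss. The estimate for compound 3 in this assay is 80000 nM, within a range from 20000 nM to 300000 nM.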

Compound 3, half-maximal inhibitory concentration: > 63000 nM
Compound 3 gave a limit, no number; the forecaster's own chance of this, stated with the estimate: 85%; the middle value lies beyond the limit too.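

In this assay compound 3 gives > 63000 nM as a limit and not a number. Going by these compounds alone, no step among compound 1, compound 2 and compound 3 can be read, and the series stands at one value: the limit of > 63000 nM in this assay, at which 3 of the 3 values shown sit. The compounds shown leave open whether any aryl group on the sulfonyl sulfur of the shared core gives a measurable inhibition value.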